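Positional Chlorine Shift on the Thiazole-Linked Aryl Group

A few compounds are considered here, and "the series" means these few. Any claim that something is new, unique, unknown or untested is made for them only; others in the source may bear on it.

Measured compounds:
compound 1 `Cc1nc(-c2ccc(Cl)s2)sc1COc1ccc2c(c1)OCC2CC(=O)O`, "not determined" (no result reported)
compound 2 `Cc1ccc(-c2nc(C)c(COc3ccc4c(c3)OCC4CC(=O)O)s2)cc1`, 73.5 nM
compound 3 `Cc1nc(-c2ccccc2Cl)sc1COc1ccc2c(c1)OCC2CC(=O)O`, "not determined" (no result reported)

Compound 3 has no number in a functional assay on CHO cells for agonist activity at Free fatty acid receptor 1 (Homo sapiens), read by FLIPR and calcium flux; on this read-out higher numbers stand for an effect only at larger amounts of compound and lower numbers for an effect already at smaller amounts ("not determined" (no result reported)); the same holds for compound 1 ("not determined" (no result reported)), so only compound 2 gives a value, 73.5 nM, in this assay. Compound 4 `Cc1nc(-c2cccc(Cl)c2)sc1COc1ccc2c(c1)OCC2CC(=O)O` arises from compound 3 by the change (3-chlorophenyl in place of 2-chlorophenyl on an aromatic carbon). Among the measured compounds shown here, no step between two measured compounds is available, so the size of the effect in this assay cannot be read from the data; a shift of the chlorine within the same aryl group is expected to change potency by no more than a moderate amount in either direction, possibly staying within the scatter. Taking compound 2 as the only anchor, compound 4 is estimated at 110 nM, with a range of 25 nM to 500 nM.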

Compound 4, half-maximal effective concentration: 138 nM
Compound 4: the middle estimate sits 1.3-fold (0.10 log units) below what was measured; the measured number falls inside the stated range.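

Placing 3-chlorophenyl where compound 2 carries 4-methylphenyl gives, in this assay, a 1.9-fold higher number from compound 2 to compound 4 (0.27 log units; within the scatter), so this position tolerates both aryl groups without a difference beyond the scatter. Steps involving compound 1 or compound 3 cannot be read, so the chlorine shift itself remains without a size. Nothing at hand explains the result. Open, on these data alone, is how 2-chlorophenyl in compound 3 compares with 3-chlorophenyl in compound 4, and whether a pyridine ring, a methoxy group or a trifluoromethyl group on the phenyl ring would keep the number in this range.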